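The source may hold more compounds than are shown below. What is called first, only, known or untested is meant among the compounds shown, and "the series" means these compounds.

Compound 1, `CCOC(=O)c1cc(-c2cccc(OCc3cccc([N+](=O)[O-])c3)c2)on1`, gives in an ADME assay on Vero cells (Chlorocebus sabaeus) for cytotoxicity, with a stated time of 72 h (a higher number here means a weaker inhibitor, a lower number a stronger inhibitor), only a limit of the assay, > 128000 nM.
Compound 2, `CCOC(=O)c1cc(-c2cccc(OCc3cccc(OC)c3)c2)on1`, gives in this assay only a limit, > 128000 nM.
Compound 3, `CCOC(=O)c1cc(-c2cccc(OCc3cc(F)cc(F)c3)c2)on1`, gives in this assay only a limit, > 128000 nM.

Compound 3 therefore stands at the limit of > 128000 nM in this assay, at which 3 of the 3 values shown sit; it has no number of its own, only the limit shared with compound 1 and compound 2. This also means that none of the steps between the three measured compounds can be read: a step that the two limits leave unreadable from compound 1 to compound 2, a step that the two limits leave unreadable from compound 1 to compound 3 and a step that the two limits leave unreadable from compound 2 to compound 3 all stay hidden behind the same limit.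

Compound 4, `CCOC(=O)c1cc(-c2cccc(OCc3ccc(F)c(F)c3F)c2)on1`, differs from compound 3 in one place: 2,3,4-trifluorophenyl in place of 3,5-difluorophenyl on a saturated chain carbon bound to an oxygen on an aromatic ring. The measured steps that bear on it are the exchanges of the ring at the same place, from compound 1 to compound 3 and from compound 2 to compound 3, and both are unreadable because all three values sit at the limit of > 128000 nM in this assay, at which 3 of the 3 values shown sit. Since every change so far has left the outcome at the limit, no step beyond the scatter is expected in this assay, and compound 4 is estimated to remain there as well, a step that the limit leaves unreadable from compound 3 to compound 4. The estimate for compound 4 is thus 200000 nM, with a range from 128000 nM to 600000 nM, most likely reported again as a limit rather than a number.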

Compound 4, half-maximal inhibitory concentration: > 128000 nM
Compound 4: a limit, no number; the forecaster's own chance of this, stated with the estimate: 90%; the middle value lies beyond the limit too.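

Compound 4, like compound 1, compound 2 and compound 3, gives only a limit in this assay, so no step among these compounds can be read: the limit of > 128000 nM in this assay, at which 4 of the 4 values shown sit.

The compounds shown leave open whether any ring on the saturated chain carbon would give a real number in this assay, and how these four compounds would rank against one another.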